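Allyl to cycloheptyl at the benzylic oxime ether carbon

This account rests on a few compounds, and the source may have more. Where it says the series, first, only, none or still open, it means among the compounds named here.

Measured compounds:
compound 1 `CC/C(=N\OC(c1ccc(OCc2ccc3ccccc3n2)cc1)C1CCCCC1)C(=O)O`, 30 nM
compound 2 `O=C(O)/C(CCc1ccccc1)=N/OC(c1ccc(OCc2ccc3ccccc3n2)cc1)C1CCCCC1`, 20 nM
compound 3 `C=CCC(O/N=C(\C)C(=O)O)c1ccc(OCc2ccc3ccccc3n2)cc1`, 142 nM

In a functional assay for inhibition of Polyunsaturated fatty acid 5-lipoxygenase (Homo sapiens) (a lower number here means a stronger inhibitor, a higher number a weaker inhibitor), compound 3 gives the highest number of the three, with compound 1 the nearest and compound 2 the furthest of the two lower numbers, both gaps beyond the scatter. Compound 4 `C/C(=N\OC(c1ccc(OCc2ccc3ccccc3n2)cc1)C1CCCCCC1)C(=O)O` is the next compound in this assay. The change from compound 3 is cycloheptyl in place of allyl on a saturated chain carbon bound to an aromatic carbon and an oxygen on an unsaturated carbon; the rest of the shared core is kept.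

Among the compounds with values here, no measured step touches this position. Within the data shown here, the only measured step, a 1.5-fold lower number from compound 1 to compound 2 (0.18 log units; within the scatter), concerns a different carbon, and it was within the scatter, so it gives no guide to the size of the present change. Among the measured compounds shown here, compounds 1 and 2 differ from compound 3 in more than one place, so their lower numbers show only that a larger group at that carbon can sit in a compound with a lower number in this assay; they do not isolate the allyl to cycloheptyl change.

On this basis a step of a 3.2-fold lower number from compound 3 to compound 4 (0.50 log units; beyond the scatter) toward a lower number is expected for compound 4, with wide uncertainty. Compound 4 is estimated at 45 nM in this assay, in the range 15 nM to 140 nM.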

Compound 4, half-maximal inhibitory concentration: 13 nM
The estimate for compound 4 lay 3.5-fold (0.54 log units) above the measured number, and the stated range ends above it.
By their numbers in this assay, from the lowest: compounds 4, 2 and 1 (each within the scatter of the next, the first and the last beyond it); then compound 3.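

In this assay, the saturated chain carbon bound to an aromatic carbon and an oxygen on an unsaturated carbon now has a single-place change of its own: cycloheptyl in place of allyl gives an 11-fold lower number from compound 3 to compound 4 (1.04 log units; beyond the scatter). Within the data shown here, earlier, compounds 1 and 2 differed from compound 3 in more than one place and could not isolate this group, while the only measured step, a 1.5-fold lower number from compound 1 to compound 2 (0.18 log units; within the scatter), concerned a different carbon; this result shows that the group at this position alone can move the number substantially. Nothing measured here accounts for the size of the step.

The change replaces 3 carbons, with one double bond and no ring, by 7 carbons in a seven-membered ring, so the contributions of the ring, the carbon count and the lost double bond remain unseparated. Still open, on these data alone, is whether cyclopentyl, an open n-heptyl chain or a piperidinyl group at this carbon would give a similarly low number, and whether the step carries over to compounds with a longer chain on the carbon with a double bond to nitrogen.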